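A few compounds are considered here, and "the series" means these few. Any claim that something is new, unique, unknown or untested is made for them only; others in the source may bear on it.

Compound 1 `OC[C@H]1OC(n2cnc3c(-c4ccc(Cl)cc4)ncnc32)[C@H](O)[C@@H]1O` gives 900 nM in a functional assay on CCRF-CEM cells (Homo sapiens) for inhibition; a higher number here means a weaker inhibitor, a lower number a stronger inhibitor.
Compound 2 `COc1cccc(-c2ncnc3c2ncn3C2O[C@H](CO)[C@@H](O)[C@H]2O)c1` gives 4800 nM in this assay.
Compound 3 `Cc1ccc(-c2ncnc3c2ncn3C2O[C@H](CO)[C@@H](O)[C@H]2O)cc1` gives 1500 nM in this assay.

Compound 3 stands second highest of the three numbers. The step nearest to it, a 1.7-fold higher number from compound 1 to compound 3 (0.22 log units; within the scatter), lies within the scatter; the furthest, a 3.2-fold lower number from compound 2 to compound 3 (0.51 log units; beyond the scatter), lies beyond it.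

Compound 4 `CCOc1ccc(-c2ncnc3c2ncn3C2O[C@H](CO)[C@@H](O)[C@H]2O)cc1` differs from compound 3 by ethoxy in place of methyl on an aromatic carbon. Going by the values given here, no measured step trades methyl for ethoxy. Among the compounds with values here, the steps that bear on it are a 5.3-fold higher number from compound 1 to compound 2 (0.73 log units; beyond the scatter) and a 3.2-fold lower number from compound 2 to compound 3 (0.51 log units; beyond the scatter), in both of which the methoxyphenyl compound carried the higher number, though at a different place on the ring. A modest upward step, a 2.0-fold higher number from compound 3 to compound 4 (0.30 log units; within the scatter), is therefore expected in this assay. Compound 4 is estimated at 3000 nM, in the range 1200 nM to 7500 nM.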

Compound 4, half-maximal inhibitory concentration: 600 nM
Compound 4: the middle estimate sits 5.0-fold (0.70 log units) above what was measured, outside the stated range (below it).
By their numbers in this assay, from the lowest: compounds 4, 1 and 3 (each within the scatter of the next, the first and the last beyond it); then compound 2.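

In this assay ethoxy is tolerated on this aromatic carbon, para to a large group, with the step to it from methyl going down (a 2.5-fold lower number from compound 3 to compound 4 (0.40 log units; beyond the scatter)), so an ether here does not carry the high number of the 3-methoxyphenyl compound (an 8.0-fold lower number from compound 2 to compound 4 (0.90 log units; beyond the scatter)). Ethoxy and chloro cannot be told apart at this position (a 1.5-fold lower number from compound 1 to compound 4 (0.18 log units; within the scatter)). No evidence on the cause of these steps is at hand.

Open, going by these compounds, is whether a longer chain such as butoxy, or an amine, holds the number on this carbon. Also open, on these data alone, is how much of the gap to the 3-methoxyphenyl compound comes from the ring place and how much from the chain.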